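Methoxy for acetyl on a shared thiocarbamate core

The source may hold more compounds than are shown below. What is called first, only, known or untested is meant among the compounds shown, and "the series" means these compounds.

The three compounds measured so far share one core, shown by `Fc1cccc(NC(=S)OCCc2ccccn2)c1` for compound 1, `O=[N+]([O-])c1cccc(NC(=S)OCCc2ccccn2)c1` for compound 2 and `CC(=O)c1ccc(NC(=S)OCCc2ccccn2)cc1` for compound 3. In an ADME assay on MT4 cells (Homo sapiens) for cytotoxicity, read by MTT assay (on this read-out higher numbers stand for lower toxicity in this test and lower numbers for higher toxicity in this test), compound 1 gives >= 100000 nM, which is a limit of the test rather than a number. In this assay compound 2 gives 100000 nM. In this assay compound 3 also gives only a limit, >= 100000 nM. Among the measured compounds shown here, the one step between measured compounds is a number no higher from compound 1 to compound 2 (the limit leaves the size open), so its size cannot be read, and as the limit of >= 100000 nM in this assay, at which 2 of the 3 values shown sit, shows, two of the three values sit at that same limit. Compound 3 therefore stands with compound 1 at the edge of what this assay can report, and compound 2 sits close by.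

Compound 4, `COc1ccc(NC(=S)OCCc2ccccn2)cc1`, differs from compound 3 by methoxy in place of acetyl on an aromatic carbon. For the measured compounds named here, no measured step concerns this exchange, so the expectation rests only on the fact that every value so far lies at or near the limit. A step of a number no higher from compound 3 to compound 4 (the limit leaves the size open) from compound 3 to compound 4 is therefore expected, meaning no change beyond the scatter. For compound 4 the estimate in this assay is 100000 nM, with a range from 50000 nM to 200000 nM, most likely again reported as a limit.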

Compound 4, half-maximal cytotoxic concentration: 48000 nM
Beside the measured number, compound 4's estimate is 2.1-fold (0.32 log units) above it; measured number outside the range, below it.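

The exchange of acetyl for methoxy, on an aromatic carbon para to a large group, gives an at least 2.0-fold lower number from compound 3 to compound 4 (0.31 log units; beyond the scatter), and it moves towards higher toxicity in this test. Among the compounds shown here, this is the first step with a size that can be read, so a change at this one place is enough to shift the read-out, something the earlier compounds, with their values at or close to the top of the range, could not show. In this assay compound 3 gives >= 100000 nM, which is a limit and not a number, and the full size of the step stays open because compound 3 stands at that limit: the limit of >= 100000 nM in this assay, at which 2 of the 4 values shown sit.

The compounds shown do not tell whether the shift comes from losing acetyl or from gaining methoxy, nor whether the same exchange on another aromatic carbon would give a similar step. They also leave open how an amine, a carboxylic acid or a longer chain such as ethoxy would read at this same place, and so whether methoxy is a special case or one example of a wider trend.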